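The source may hold more compounds than are shown below. What is called first, only, known or untested is meant among the compounds shown, and "the series" means these compounds.

Compound 3, `CC(C)COC(=O)N1CCN(C(=O)c2nc(Nc3cc(C4CC4)[nH]n3)c3cc(Cl)ccc3n2)C[C@H]1C`, sits second highest of the three compounds measured in an assay for inhibition of serine/threonine-protein kinase PAK 4 (Homo sapiens), read by FRET and Z'-LYTE, with a stated time of 60 min, tested at 50 uM, in the presence of a further agent that is not named here; on this read-out higher numbers stand for a stronger effect at the one concentration tested and lower numbers for a weaker effect; in that assay compound 3 gives 46.9%. Compound 1, `CCCCCOC(=O)N1CCN(C(=O)c2nc(Nc3cc(C4CC4)[nH]n3)c3cc(Cl)ccc3n2)C[C@H]1C`, gives 32.7%, and compound 2, `C[C@@H]1CN(C(=O)c2nc(Nc3cc(C4CC4)[nH]n3)c3cc(Cl)ccc3n2)CCN1C(=O)OCC(Cl)(Cl)Cl`, gives 82.8%. All three differ only on a saturated chain carbon bound to an oxygen next to a carbonyl group, and every measured step moved the number beyond the scatter: a number 14.2 percentage points higher from compound 1 to compound 3 (beyond the scatter), a number 50.1 percentage points higher from compound 1 to compound 2 (beyond the scatter) and a number 35.9 percentage points lower from compound 2 to compound 3 (beyond the scatter).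

Compound 4, `CC(C)C(=O)OCOC(=O)N1CCN(C(=O)c2nc(Nc3cc(C4CC4)[nH]n3)c3cc(Cl)ccc3n2)C[C@H]1C`, changes the same position again: (isopropylcarbonyl)oxy in place of isopropyl on a saturated chain carbon bound to an oxygen next to a carbonyl group. The group that enters is unlike either the trichloromethyl of compound 2 or the butyl of compound 1, so none of the three steps points to its direction; they only show that this position can shift the read-out by large amounts either way. The expectation for compound 4 is therefore held close to compound 3, and the step is expected to be a number 3.1 percentage points higher from compound 3 to compound 4 (within the scatter), within the scatter. Compound 4 is estimated at 50%, with a range from 25% to 75%.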

Compound 4, a percentage reported as inhibition, at one concentration (the size of the read-out at that concentration, not a potency) in the serine/threonine-protein kinase PAK 4 assay: 86.9%
Compound 4: the middle estimate sits 36.9 percentage points below what was measured; measured number above the stated range.
By their numbers in the serine/threonine-protein kinase PAK 4 assay, from the lowest: compound 1; then compound 3; then compounds 2 and 4 (each within the scatter of the next).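

In the serine/threonine-protein kinase PAK 4 assay, (isopropylcarbonyl)oxy gives a number 40 percentage points higher from compound 3 to compound 4 (beyond the scatter) and a number 54.2 percentage points higher from compound 1 to compound 4 (beyond the scatter), showing that a group containing oxygen and a carbonyl can raise the read-out at this position by a large amount. Going by these compounds alone, the trichloromethyl of compound 2 is no longer the only group linked to a high read-out, since a number 4.1 percentage points higher from compound 2 to compound 4 (within the scatter) places two very different groups within the scatter of each other. In a physicochemical assay, read by HPLC, in phosphate buffer, with a stated time of 2 h, at pH 7.4 (a lower number here means that less of the compound is left, a higher number that more of the compound is left), compound 3 has 99% remaining and compound 4 has 93.5%, with a number 5.5 percentage points lower from compound 3 to compound 4 (within the scatter), so the change that moved the kinase read-out so far did not move this one beyond the scatter.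

Nothing given here accounts for the rise seen with compound 4. On these data alone, it remains open how the read-out would respond if an amine, a carboxylic acid or a longer chain stood in place of the isopropyl within the (isopropylcarbonyl)oxy group.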